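The source may report more compounds than this note shows. Statements on the series, on what has been measured and on what is new or still open speak of the compounds shown alone.

Measured compounds:
compound 1 `CCCSc1nc(N/N=C/c2ccc(C)cc2)c2nnn(Cc3ccccc3)c2n1` — > 64000 nM
compound 2 `CCCSc1nc(N/N=C(\C)c2ccccc2O)c2nnn(Cc3ccccc3Cl)c2n1` — 35000 nM
compound 3 `CCCSc1nc(N/N=C(\C)c2ccccc2O)c2nnn(Cc3cccc(Cl)c3)c2n1` — 6500 nM

In a functional assay on MGC-803 cells (Homo sapiens) for antiproliferative activity, read by MTT assay, with a stated time of 72 h (a higher number here means a weaker inhibitor, a lower number a stronger inhibitor), compound 1 gives > 64000 nM, which is a limit of the assay and not a number; it sits at the limit of > 64000 nM in this assay, at which 1 of the 3 values shown sits, so compound 1 stands at the weak end of the values shown, with its true value unknown. Compound 4 `CCCSc1nc(N/N=C(\C)c2ccccc2)c2nnn(Cc3ccccc3)c2n1` has not been measured. It differs from compound 1 as follows: a group of 9 heavy atoms (8 carbon, 1 nitrogen; one six-membered aromatic ring of carbon only) in place of a group of 9 heavy atoms (8 carbon, 1 nitrogen; one six-membered aromatic ring of carbon only), on a nitrogen on an aromatic ring.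

Among the compounds with values here, the one measured step, a 5.4-fold lower number from compound 2 to compound 3 (0.73 log units; beyond the scatter), concerns a chlorophenyl on a saturated chain carbon, not the part changed here, so it does not bear on the step from compound 1 to compound 4. Compounds 2 and 3 differ from compound 4 in more than one place. Compound 2 gives 35000 nM and compound 3 gives 6500 nM, which only show that close relatives of this core reach measurable inhibition.

Within the data shown here, with no directly relevant step, a modest change is expected, an at least 1.6-fold lower number from compound 1 to compound 4 (0.20 log units; that floor lies within the scatter), toward a measurable value. Compound 4 is estimated at 40000 nM, range 9000 nM to 130000 nM, with a fair chance that only a limit is returned.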

Compound 4, half-maximal inhibitory concentration: 25400 nM
For compound 4 the middle estimate is 1.6-fold (0.20 log units) above the measured one, and the stated range covers the measured number.
By their numbers in this assay, from the lowest: compound 3; then compounds 4 and 2 (each within the scatter of the next). At a limit, above all of these: compound 1.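

In this assay, exchanging one group for another on a nitrogen on an aromatic ring, with the same atoms joined differently, gives an at least 2.5-fold lower number from compound 1 to compound 4 (0.40 log units; beyond the scatter). Within the data shown here, this is the first reading at this position, as the earlier measured step concerned only the chlorophenyl on a saturated chain carbon, and it shows that activity here responds to a change that leaves the heavy-atom, donor and acceptor counts as they were. The step can be given only as a bound because the value for compound 1 is a limit of the assay: the limit of > 64000 nM in this assay, at which 1 of the 4 values shown sits.

From the compounds shown here alone, the true size of the step therefore remains open. Also open, going by these compounds, is how this position would respond to a group carrying an amine or a carboxylic acid, or to a longer chain in place of the small group changed here.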